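Phenyl to Cyclohexyl on a Weak Receptor Binder

A few compounds are considered here, and "the series" means these few. Any claim that something is new, unique, unknown or untested is made for them only; others in the source may bear on it.

Compound 1 `CCCCCCCN1C(=N)NC[C@@H]1CCCCN1C[C@@H](Cc2ccccc2)N(CC2CCC(C(C)(C)C)CC2)C1=N` gives 54400 nM in an assay on HEK293 cells for displacement of a labelled ligand from Neuronal acetylcholine receptor; alpha3/beta4 (Rattus norvegicus), with a stated time of 2 h; a lower number here means a stronger inhibitor, a higher number a weaker inhibitor.
Compound 2 `CCCCCCCN1C(=N)NC[C@@H]1CCCCN1C[C@@H](CC2CCCCC2)N(CC2CCC(C(C)(C)C)CC2)C1=N` gives 55100 nM in this assay.
Compound 3 `CC(C)CCCN1C(=N)NC[C@@H]1CCCCN1C[C@@H](Cc2ccccc2)N(CC2CCC(C(C)(C)C)CC2)C1=N` gives 68400 nM in this assay.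

Compound 3 shows the highest of the three numbers, but its gaps to compound 1 and to compound 2 both fall within the scatter, so no order among the three can be claimed. Compound 4 `CC(C)CCCN1C(=N)NC[C@@H]1CCCCN1C[C@@H](CC2CCCCC2)N(CC2CCC(C(C)(C)C)CC2)C1=N` differs from compound 3 by cyclohexyl in place of phenyl on a saturated chain carbon bound to a saturated ring carbon. This exchange has been measured once already, between two compounds that otherwise match each other: a 1.0-fold higher number from compound 1 to compound 2 (0.01 log units; within the scatter). That step gave no movement beyond the scatter, so the step of a 1.0-fold higher number from compound 3 to compound 4 (0.00 log units; within the scatter) is expected to be likewise flat, in no particular direction. Compound 4 is therefore estimated at 69000 nM, with a range from 35000 nM to 140000 nM.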

Compound 4, inhibition constant: 78400 nM
For compound 4 the middle estimate is 1.1-fold (0.06 log units) below the measured one; the measured number falls inside the stated range.
By their numbers in this assay, from the lowest: compounds 1, 2, 3 and 4 (each within the scatter of the next).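

Cyclohexyl in place of phenyl now gives a 1.1-fold higher number from compound 3 to compound 4 (0.06 log units; within the scatter), so this exchange stays flat on a second core as well: the same change on two cores in this assay, a 1.0-fold higher number (0.01 log units; within the scatter) from compound 1 to compound 2 and a 1.1-fold higher number (0.06 log units; within the scatter) from compound 3 to compound 4, 1.1-fold (0.05 log units) apart, within the scatter of two such steps

Isopropyl in place of butyl gives a 1.4-fold higher number from compound 2 to compound 4 (0.15 log units; within the scatter), so the chain change is also flat with cyclohexyl present instead of phenyl: the same change on two cores in this assay, a 1.3-fold higher number (0.10 log units; within the scatter) from compound 1 to compound 3 and a 1.4-fold higher number (0.15 log units; within the scatter) from compound 2 to compound 4, 1.1-fold (0.05 log units) apart, within the scatter of two such steps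

Neither change moves the number beyond the scatter with either partner group.

Still open, as far as these compounds go, is whether a group of another kind, such as an amine or a carboxylic acid, on a saturated chain carbon bound to a saturated ring carbon would move the number beyond the scatter.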